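Allyl and a longer acid chain on the amide nitrogen

The compounds below may be only part of what the source reports. "The series", "measured", "known", "first", "only" and "open" are said of these compounds alone.

The shared core of compound 2 `CCN(CC(=O)O)C(=O)/C(C)=C/c1ccc(C(=O)Oc2ccc(C(=N)N)cc2)cc1` carries an ester-linked amidinophenyl group, and in an in vitro ADME assay on a cell-free system (plasma) for pharmacokinetics (on this read-out lower numbers stand for a shorter-lived compound and higher numbers for a longer-lived compound), compound 2 gives 1 h, the only number shown in this assay. Compound 1 `C=CCN(CCC(=O)OCC)C(=O)/C(C)=C/c1ccc(C(=O)Oc2ccc(C(=N)N)cc2)cc1`, which carries allyl(2-(ethoxycarbonyl)ethyl)amino in place of (carboxymethyl)(ethyl)amino on the carbonyl carbon, reports only a limit of < 0.0167 h in this assay. Among the compounds with values here, the step of an at least 59-fold higher number from compound 1 to compound 2 (1.77 log units; beyond the scatter) is the sole measured step, and it rests on (the limit of < 0.0167 h in this assay, at which 1 of the 2 values shown sits).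

Compound 3 `C=CCN(CCC(=O)O)C(=O)/C(C)=C/c1ccc(C(=O)Oc2ccc(C(=N)N)cc2)cc1` differs from compound 2 by allyl(2-carboxyethyl)amino in place of (carboxymethyl)(ethyl)amino on a carbonyl carbon. Within the data shown here, this change keeps a free carboxylic acid on the chain but restores the allyl group of compound 1; the measured step changed both groups at once, so no step isolates the effect of either. The account therefore expects a step of no change at the digits printed from compound 2 to compound 3 (within the scatter) of no size beyond the scatter, and estimates compound 3 at 1 h in this assay, between 0.3 h and 3 h.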

Compound 3, half-life: 0.783 h
Estimate against measurement, compound 3: 1.3-fold (0.11 log units) above; the measured number falls inside the stated range.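

In this assay, the ester and the free carboxylic acid are now separated from the other changes: with the allyl group and chain length kept, hydrogen in place of ethyl on an oxygen next to a carbonyl group gives an at least 46-fold higher number from compound 1 to compound 3 (1.67 log units; beyond the scatter). That step rests on a limit: the limit of < 0.0167 h in this assay, at which 1 of the 3 values shown sits. Between the two free acids, allyl(2-carboxyethyl)amino in place of (carboxymethyl)(ethyl)amino on a carbonyl carbon gives a 1.3-fold lower number from compound 2 to compound 3 (0.11 log units; within the scatter), so this joint change of both groups on the amide nitrogen leaves the read-out within the scatter.

Going by these compounds, the allyl group and the chain length changed together in that step, so their separate contributions remain open, and either could hide an effect offset by the other. On these data alone, it also remains open how a primary amide or a longer chain ending in a carboxylic acid would read at this position.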